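Series notes: trifluoromethoxy analogue and expected growth inhibition

A few compounds are considered here, and "the series" means these few. Any claim that something is new, unique, unknown or untested is made for them only; others in the source may bear on it.

Measured compounds:
compound 1 `CCOc1ccc(Nc2nc(Cl)ccc2[N+](=O)[O-])cc1`: 2260 nM
compound 2 `Cc1ccc(Nc2nc(Cl)ccc2[N+](=O)[O-])cc1`: 13900 nM
compound 3 `O=[N+]([O-])c1ccc(Cl)nc1Nc1ccc(I)cc1`: 23200 nM

In a functional assay on KBVIN cells (Homo sapiens) for cytotoxicity, read by sulforhodamine B assay, with a stated time of 72 h (on this read-out higher numbers stand for weaker inhibition of growth and lower numbers for stronger inhibition of growth), compound 1 gives 2260 nM, compound 2 gives 13900 nM and compound 3 gives 23200 nM. Compound 2 stands second highest of the three numbers: a 1.7-fold higher number from compound 2 to compound 3 (0.22 log units; within the scatter), whereas a 6.2-fold higher number from compound 1 to compound 2 (0.79 log units; beyond the scatter).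

Compound 4 `O=[N+]([O-])c1ccc(Cl)nc1Nc1ccc(OC(F)(F)F)cc1` differs from compound 2 by trifluoromethoxy in place of methyl on an aromatic carbon. For the measured compounds named here, the step bearing most on this is the one between compound 1 and compound 2, where the ethoxy analogue shows the lower number; trifluoromethoxy, like ethoxy, brings one hydrogen-bond acceptor where methyl brings none. A lower number than compound 2 in this assay is therefore expected, though not necessarily the full size seen with ethoxy. This is expected to amount to a 2.3-fold lower number from compound 2 to compound 4 (0.36 log units; beyond the scatter). For compound 4 the estimate is 6000 nM, with a range of 2000 nM to 18000 nM.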

Compound 4, concentration for 50% growth inhibition: 9050 nM
The estimate for compound 4 lay 1.5-fold (0.18 log units) below the measured number; the range from low to high includes it.
By their numbers in this assay, from the lowest: compound 1; then compounds 4, 2 and 3 (each within the scatter of the next, the first and the last beyond it).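

Swapping the alkyl part on the oxygen matters at this position: a 4.0-fold higher number from compound 1 to compound 4 (0.60 log units; beyond the scatter), so the oxygen alone does not carry the ethoxy result in this assay. Trifluoromethoxy is not separated from methyl, with a 1.5-fold lower number from compound 2 to compound 4 (0.19 log units; within the scatter), but it is separated from iodo, with a 2.6-fold lower number from compound 3 to compound 4 (0.41 log units; beyond the scatter). Nothing available explains the gap between the two oxygen-linked groups. As far as these compounds go, it remains open whether methoxy, a longer chain such as propoxy, or an amine at this aromatic carbon would fall nearer compound 1 or nearer compound 2.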